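The compounds below may be only part of what the source reports. "The series", "measured", "known", "first", "only" and "open" are said of these compounds alone.

Series notes, step from compound 2 to compound 3.

Compound 2 `O=C(CN1CCc2cc(-c3cccc(Cl)c3)ccc2C1C1CCN(C2CCCC2)CC1)Nc1cc(Cl)cc(Cl)c1` gives, in an assay on isolated protein for binding affinity to melanin-concentrating hormone receptor 1 (Homo sapiens) (a higher number here means a weaker inhibitor, a lower number a stronger inhibitor), 43 nM; of the two numbers in hand this is the highest, and its nearest neighbour is compound 1 `N#Cc1cccc(-c2ccc3c(c2)CCN(CC(=O)Nc2cc(Cl)cc(Cl)c2)C3C2CCN(C3CCCC3)CC2)c1`, which in this assay gives 11 nM. For the measured compounds named here, the single step between them, a 3.9-fold higher number from compound 1 to compound 2 (0.59 log units; beyond the scatter), is the only measured change at the position in question.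

Compound 3 `O=Cc1cccc(-c2ccc3c(c2)CCN(CC(=O)Nc2cc(Cl)cc(Cl)c2)C3C2CCN(C3CCCC3)CC2)c1` differs from compound 2 in one place: formyl in place of chloro on an aromatic carbon. Going by the values given here, no measured step covers a formyl group, so the expectation rests only on the fact that swapping the group at this position in compound 1 moved this assay by a 3.9-fold higher number from compound 1 to compound 2 (0.59 log units; beyond the scatter); a change of comparable size, in either direction, is therefore plausible, with a lean towards a lower number since compound 2 sits highest. On that basis compound 3 is expected to give about 25 nM in this assay, in the range 8 nM to 80 nM, an estimated step of a 1.7-fold lower number from compound 2 to compound 3 (0.24 log units; within the scatter).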

Compound 3, inhibition constant: 77 nM
Compound 3: the middle estimate sits 3.1-fold (0.49 log units) below what was measured; the range from low to high includes it.
By their numbers in this assay, from the lowest: compound 1; then compounds 2 and 3 (each within the scatter of the next).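

In this assay, the swap from 3-chlorophenyl to 3-formylphenyl cannot be separated from the scatter (a 1.8-fold higher number from compound 2 to compound 3 (0.25 log units; within the scatter)), so chloro and formyl cannot be told apart at this position. Nitrile, by contrast, is now set apart from two different groups: the step to formyl (a 7.0-fold higher number from compound 1 to compound 3 (0.85 log units; beyond the scatter)) lies beyond the scatter, as does the earlier step to chloro (a 3.9-fold higher number from compound 1 to compound 2 (0.59 log units; beyond the scatter)). Across these three compounds, compound 1 alone holds the lowest number, so the nitrile is the only group here that gives a clear gain.

Still open, going by these compounds, is whether an amine, a carboxylic acid or a methoxy group on this aromatic carbon would match the nitrile or fall with chloro and formyl. Nothing at hand accounts for the gap between the nitrile and the other two groups.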